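A Change of Ring on the Triple-Bonded Carbon

A few compounds are considered here, and "the series" means these few. Any claim that something is new, unique, unknown or untested is made for them only; others in the source may bear on it.

Compound 1, `CCCCCCc1ccc(C#CC#Cc2cn([C@H]3C[C@H](O)[C@@H](CO)O3)c(=O)[nH]c2=O)cc1`, in an ADME assay on HEL cells (Homo sapiens) for cytotoxicity, read by microscopy (a lower number here means that less compound is tolerated, a higher number that more compound is tolerated), gives 100000 nM.
Compound 2, `O=c1[nH]c(=O)n([C@H]2C[C@H](O)[C@@H](CO)O2)cc1C#CC#Cc1ccccn1`, gives only a limit of the assay, > 20000 nM.
Compound 3, `O=c1[nH]c(=O)n([C@H]2C[C@H](O)[C@@H](CO)O2)cc1C#CC#Cc1ccc(OC(F)(F)F)cc1`, gives 100000 nM.
Compound 4, `Cc1cc(C#CC#Cc2cn([C@H]3C[C@H](O)[C@@H](CO)O3)c(=O)[nH]c2=O)ccc1F`, has not yet been measured.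

Among the compounds with values here, compound 2 therefore stands at a limit rather than at a number: the reading is the limit of > 20000 nM in this assay, at which 1 of the 3 values shown sits, and no step from it can be sized. The move to compound 4 is a replacement of the whole ring at the end of the diyne, (4-fluoro-3-methylphenyl in place of pyridin-2-yl on a triple-bonded carbon).

Within the data shown here, only one step among the measured compounds is sized, no change at the digits printed from compound 1 to compound 3 (within the scatter). It changes a substituent on an aromatic carbon and leaves the carbon-only ring in place, so it bears on the move to compound 4 only indirectly; still, both compounds carrying a carbon-only ring at that position, compound 1 and compound 3, sit at the same tolerated concentration. On that basis compound 4, which also carries a carbon-only ring there, is expected to be tolerated as well, and the estimated step that the limit leaves unreadable from compound 2 to compound 4 is expected to be toward a higher tolerated concentration, though a limit on compound 4 as well would not be surprising. The estimate for compound 4 is 100000 nM, within 30000 nM to 100000 nM.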

Compound 4, minimum cytotoxic concentration: 100000 nM
For compound 4 middle estimate and measured number coincide at the digits printed; the measured number falls inside the stated range.
By their numbers in this assay, from the lowest: compounds 1, 3 and 4 (each within the scatter of the next).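

No new step can be read from compound 4: the change from compound 2 to compound 4 cannot be sized, because compound 2 stands at a limit of the assay rather than at a number in this assay: the limit of > 20000 nM in this assay, at which 1 of the 4 values shown sits. The compounds shown leave open how pyridin-2-yl and 4-fluoro-3-methylphenyl at the end of the diyne compare in this read-out.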